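Trimethoxy chalcones: moving the aryl substituent to para-fluoro

The compounds below may be only part of what the source reports. "The series", "measured", "known", "first", "only" and "open" are said of these compounds alone.

Three chalcones have been tested in a functional assay on NCI-H727 cells (Homo sapiens) for cytotoxicity, with a stated time of 48 h; on this read-out higher numbers stand for weaker inhibition and lower numbers for stronger inhibition. Compound 1 `COc1cc(O)c(C(=O)/C=C/c2ccc(F)cc2)c(OC)c1` carries a free hydroxyl on its core; compound 1 reaches only the assay limit, > 20000 nM. Compound 2 `COc1cc(OC)c(C(=O)/C=C/c2ccc(Br)cc2)c(OC)c1` gives 11300 nM, and compound 3 `COc1cc(OC)c(C(=O)/C=C/c2ccccc2SC)c(OC)c1` gives 8700 nM. Among the two plain numbers compound 3 sits alongside compound 2, the change from compound 2 to compound 3 being a 1.3-fold lower number from compound 2 to compound 3 (0.11 log units; within the scatter). Compound 4 `COc1cc(OC)c(C(=O)/C=C/c2ccc(F)cc2)c(OC)c1` is now to be measured; it differs from compound 3 only in the aryl group: 4-fluorophenyl in place of 2-(methylsulfanyl)phenyl on a double-bonded chain carbon bound to a double-bonded chain carbon. Within the data shown here, the one comparable swap of this aryl group was within the scatter, and compound 1, bearing the same 4-fluorophenyl, sat at the limit (the limit of > 20000 nM in this assay, at which 1 of the 3 values shown sits). A step of a 1.7-fold higher number from compound 3 to compound 4 (0.24 log units; within the scatter) toward weaker inhibition is therefore expected. Compound 4 is estimated at 15000 nM, between 6000 nM and 40000 nM.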

Compound 4, half-maximal inhibitory concentration: 5500 nM
Compound 4: middle estimate off by 2.7-fold (0.44 log units), on the high side; the measured number lies below the stated range.
By their numbers in this assay, from the lowest: compounds 4, 3 and 2 (each within the scatter of the next, the first and the last beyond it). At a limit, above all of these: compound 1.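

Keeping the 4-fluorophenyl fixed, methyl in place of hydrogen on an oxygen on the core gives an at least 3.6-fold lower number from compound 1 to compound 4 (0.56 log units; beyond the scatter), and compound 1 stands at a limit, so this step is only a floor: the limit of > 20000 nM in this assay, at which 1 of the 4 values shown sits. Fluoro in place of bromo on an aromatic carbon gives a 2.1-fold lower number from compound 2 to compound 4 (0.31 log units; beyond the scatter), a modest change. The swap itself gives a 1.6-fold lower number from compound 3 to compound 4 (0.20 log units; within the scatter), so 4-fluorophenyl and 2-(methylsulfanyl)phenyl cannot be ordered here.

Still open, as far as these compounds go, is what an amine or a carboxylic acid on this aryl ring would do. From the compounds shown here alone, whether the methyl step holds with other aryl groups is also open.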